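The compounds below may be only part of what the source reports. "The series", "measured", "known", "first", "only" and "open" are said of these compounds alone.

Compound 1 `Fc1cccc(-c2cn(C3CN4CCC3CC4)nn2)c1` gives 748 nM in an assay on HEK293 cells for displacement of a labelled ligand from Neuronal acetylcholine receptor; alpha4/beta2 (Homo sapiens), read by scintillation counting, with a stated time of 120 min (a higher number here means a weaker inhibitor, a lower number a stronger inhibitor), the lowest of the two numbers in hand. Among the measured compounds shown here, the only other measured compound, compound 2 `Fc1cccc(-c2cn([C@H]3CN4CCC3CC4)nn2)c1`, gives 5200 nM in this assay, and the one measured step, a 7.0-fold higher number from compound 1 to compound 2 (0.84 log units; beyond the scatter), concerns only the drawn configuration at a saturated ring carbon (the fact that one of compounds 1 and 2 is drawn with a defined configuration and the other without, at the place where they differ). Compound 3 `FCCOc1cccc(-c2cn(C3CN4CCC3CC4)nn2)c1` instead changes the aromatic substituent: 2-fluoroethoxy in place of fluoro on an aromatic carbon. For the measured compounds named here, no measured step touches that position, so the expectation for this assay rests on the change alone and stays small, a 1.5-fold higher number from compound 1 to compound 3 (0.17 log units; within the scatter). Compound 3 is estimated at 1100 nM, with a range from 250 nM to 5000 nM.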

Compound 3, inhibition constant: 1960 nM
Estimate against measurement, compound 3: 1.8-fold (0.25 log units) below; the measured number falls inside the stated range.
By their numbers in this assay, from the lowest: compound 1; then compound 3; then compound 2.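

In this assay, 2-fluoroethoxy in place of fluoro on the aromatic carbon gives a 2.6-fold higher number from compound 1 to compound 3 (0.42 log units; beyond the scatter), the first measured sign that this position responds to its substituent. The entering group has 4 heavy atoms against 1 and adds a hydrogen-bond acceptor, yet the step stays modest. No measured fact shown here accounts for this step.

The compounds shown do not separate the effect of the ether oxygen from that of the chain or its fluorine. A methoxy group or a longer 3-fluoropropoxy chain on this carbon would bear on that question.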